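Working notes: methylamino to ethylamino on the acetamide chain

The compounds below may be only part of what the source reports. "The series", "measured", "known", "first", "only" and "open" are said of these compounds alone.

Values in a functional assay on A2780 cells (Homo sapiens) for antiproliferative activity, read by MTT assay, with a stated time of 48 h; a higher number here means a weaker inhibitor, a lower number a stronger inhibitor:
- Compound 1 `COc1ccc(C(=O)c2ccc(OC)c3c2OC(C)(C)C=C3)c(NC(=O)CBr)c1`: 980 nM
- Compound 2 `CNCC(=O)Nc1cc(OC)ccc1C(=O)c1ccc(OC)c2c1OC(C)(C)C=C2`: 620 nM
- Compound 3 `CCNCC(=O)Nc1cc(OC)ccc1C(=O)c1ccc(OC)c2c1OC(C)(C)C=C2`: not yet measured

Among the measured compounds shown here, only two numbers exist so far in this assay, and compound 2 cannot be ranked against compound 1, since the two values lie within the scatter of each other. For the measured compounds named here, the single measured step is a 1.6-fold lower number from compound 1 to compound 2 (0.20 log units; within the scatter), with methylamino in place of bromo.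

Compound 3 differs from compound 2 by methyl in place of hydrogen on a saturated chain carbon bound to an amine nitrogen. In words, this is methyl in place of hydrogen on a saturated chain carbon bound to an amine nitrogen, or methylamino to ethylamino.

Going by the values given here, no measured step covers this exact change, so the evidence is thin. Among the compounds with values here, the only guide is compound 2, reached by a 1.6-fold lower number from compound 1 to compound 2 (0.20 log units; within the scatter), a larger replacement of the group that did not move the number beyond the scatter. A step beyond the scatter is therefore not expected here, in either direction. The expected step is a 1.0-fold lower number from compound 2 to compound 3 (0.01 log units; within the scatter). Compound 3 is estimated at 600 nM, with an expected range of 280 nM to 1300 nM.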

Compound 3, half-maximal inhibitory concentration: 1980 nM
Compound 3: the middle estimate sits 3.3-fold (0.52 log units) below what was measured; the whole stated range lies below it.
By their numbers in this assay, from the lowest: compounds 2 and 1 (each within the scatter of the next); then compound 3.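

In this assay, the saturated chain carbon bound to an amine nitrogen responds to even a small change: methyl in place of hydrogen, which turns methylamino into ethylamino, gives a 3.2-fold higher number from compound 2 to compound 3 (0.50 log units; beyond the scatter). Among the compounds shown here, until now, the only measured step on this chain, methylamino in place of bromo, had stayed within the scatter, so the size of a replacement does not by itself set the size of the step in this short series. Ethylamino in place of bromo gives a 2.0-fold higher number from compound 1 to compound 3 (0.31 log units; beyond the scatter), which separates the ethylamino compound from the bromo compound in the direction of the higher number, and nothing available bears on the reason for either step.

With a single step at this position, the compounds shown cannot tell whether the number keeps climbing with a longer chain such as propylamino or a branched one such as isopropylamino, or whether ethyl is an isolated case. Also open, as far as these compounds go, is how the series responds to a dimethylamino group, which has no hydrogen on the amine nitrogen, or to a cyclic amine such as morpholine at the end of the chain.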